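The source may hold more compounds than are shown below. What is called first, only, known or untested is meant among the compounds shown, and "the series" means these compounds.

Measured compounds:
- Compound 1, `O=C(CN(C(=O)C1CCOCC1)C1CCCCC1)Nc1cc(F)cc(F)c1`, in an assay on HEK293 cells for inhibition of sodium- and chloride-dependent glycine transporter 1 (Homo sapiens), read by scintillation proximity assay (a higher number here means a weaker inhibitor, a lower number a stronger inhibitor), compound 1 gives 5010 nM.
- Compound 2, `O=C(CN(C(=O)c1ccc(-c2ccccn2)cc1)C1CCCOC1)Nc1cc(F)cc(F)c1`, in this assay compound 2 gives 79.4 nM.

Of the two numbers, compound 2 holds the lower one, and its gap to compound 1 is well beyond the scatter of repeated runs. The two compounds differ in more than one place, so nothing can be said about which of those differences carries the gap; only the two values themselves are known.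

Compound 3, `O=C(CN(CC1CCC1)C(=O)c1ccc(-c2ccccn2)cc1)Nc1cc(F)cc(F)c1`, is the next compound and has not yet been measured in this assay. It differs from compound 2 in one place: cyclobutylmethyl in place of oxan-3-yl on an amide-type nitrogen, so the ring oxygen of the oxan-3-yl group is gone and a smaller all-carbon ring sits on the saturated chain carbon instead.

No comparable single change has been measured here, so the size of the step is open. The expected step from compound 2 to compound 3 is a 1.4-fold higher number from compound 2 to compound 3 (0.14 log units; within the scatter), a small shift that may well stay within the scatter, with a slight lean toward a weaker inhibitor. Compound 3 is therefore expected to give about 110 nM, estimated to lie between 30 nM and 400 nM.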

Compound 3, half-maximal inhibitory concentration: 126 nM
Compound 3: the middle estimate sits 1.1-fold (0.06 log units) below what was measured; low and high end bracket the measured number.
By their numbers in this assay, from the lowest: compounds 2 and 3 (each within the scatter of the next); then compound 1.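

In this assay, putting cyclobutylmethyl in place of oxan-3-yl on the amide-type nitrogen gives a 1.6-fold higher number from compound 2 to compound 3 (0.20 log units; within the scatter). With the rest of the molecule held fixed, this nitrogen can therefore lose the ring oxygen and the hydrogen-bond acceptor it counts as, and take a four-membered all-carbon ring instead, with no difference beyond the scatter. No measurement here bears on why these two groups read alike.

This single pair cannot show whether the same holds for quite different groups on this nitrogen, such as a chain ending in an amine, a carboxylic acid or a longer straight carbon chain. Compound 1 differs from compound 2 and compound 3 in more than one place, so it cannot show what the group on this nitrogen contributes on its own.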